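Carbonyl-side exchange from compound 3 to compound 4

A few compounds are considered here, and "the series" means these few. Any claim that something is new, unique, unknown or untested is made for them only; others in the source may bear on it.

In a functional assay on PC-3 cells (Homo sapiens) for inhibition, read by MTT assay, with a stated time of 48 h (on this read-out lower numbers stand for stronger inhibition and higher numbers for weaker inhibition), compound 1 (`COc1cc(-c2nnc(SCc3ccc(C)cc3)n2-c2ccc(N(C)C)cc2)cc(OC)c1OC`) gives 37300 nM and compound 2 (`COc1cc(-c2nnc(SCc3ccc(F)cc3)n2-c2ccc(N(C)C)cc2)cc(OC)c1OC`) gives 46500 nM with the step between them (a 1.2-fold higher number from compound 1 to compound 2 (0.10 log units; within the scatter)) showing no separation. Compound 3 (`COc1ccc(C(=O)CSc2nnc(-c3cc(OC)c(OC)c(OC)c3)n2-c2ccc(N(C)C)cc2)cc1O`) carries no number, only a limit (> 100000 nM). The two steps into that limit (an at least 2.6-fold higher number from compound 1 to compound 3 (0.42 log units; beyond the scatter) and an at least 2.1-fold higher number from compound 2 to compound 3 (0.33 log units; beyond the scatter)) are bounds and not sizes.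

Compound 4 (`COc1ccc(NC(=O)CSc2nnc(-c3cc(OC)c(OC)c(OC)c3)n2-c2ccc(N(C)C)cc2)cc1`) has (4-methoxyphenyl)amino in place of 3-hydroxy-4-methoxyphenyl on a carbonyl carbon. Going by the values given here, no measured step covers this exchange, and compound 3 is the only measured compound with a carbonyl on the chain. The two bounds therefore give only a rough guide. Among the compounds with values here, the expectation rests on the weak readings so far, with compound 1 at 37300 nM and compound 2 at 46500 nM as the only numbers. In this assay a modest move to a lower number is expected if a number appears at all, and a second limit is a real possibility. The estimated step (an at least 2.0-fold lower number from compound 3 to compound 4 (0.30 log units; that floor lies within the scatter)) can only be read against a limit. Compound 4 is estimated at 50000 nM (expected range 12000 nM to 150000 nM).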

Compound 4, half-maximal inhibitory concentration: 56100 nM
The estimate for compound 4 lay 1.1-fold (0.05 log units) below the measured number, within the range that was stated.
By their numbers in this assay, from the lowest: compounds 1, 2 and 4 (each within the scatter of the next). At a limit, above all of these: compound 3.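

In this assay the (4-methoxyphenyl)carbamoyl group on the saturated chain carbon bound to a sulfur cannot be told apart from 4-methylphenyl or 4-fluorophenyl at that place, with a 1.5-fold higher number from compound 1 to compound 4 (0.18 log units; within the scatter) and a 1.2-fold higher number from compound 2 to compound 4 (0.08 log units; within the scatter). A carbonyl on this chain therefore does not always go with a limit reading, as compound 3 alone could have suggested, and the exchange on the carbonyl carbon gives an at least 1.7-fold lower number from compound 3 to compound 4 (0.25 log units; that floor lies within the scatter), which is a floor and not a size. Compound 3 remains the only compound here held at a limit of the assay: the limit of > 100000 nM in this assay, at which 1 of the 4 values shown sits.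

Compound 3 and compound 4 differ both in the amino link to the carbonyl carbon and in the hydroxy group on the aromatic ring, and no compound shown separates these two changes. Also open is how the reading in this assay would respond to a simple amine, a carboxylic acid or a longer chain at this place on the saturated chain carbon, since all the compounds shown carry an aromatic ring there.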